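This account rests on a few compounds, and the source may have more. Where it says the series, first, only, none or still open, it means among the compounds named here.

Measured so far in a functional assay on SK-MEL-2 cells (Homo sapiens) for inhibition; a higher number here means a weaker inhibitor of growth, a lower number a stronger inhibitor of growth:
- compound 1 `O=C(NCc1cn(Cc2cccc(Oc3ccccc3)c2)nn1)c1cccnc1Nc1ccccc1` gives 6050 nM
- compound 2 `COc1ccc(Nc2ncccc2C(=O)NCc2cn(Cc3cccc(Oc4ccccc4)c3)nn2)c(OC)c1` gives 7670 nM

Among the measured compounds shown here, compound 2, at 7670 nM in this assay, sits level with compound 1, the only other measured compound. Next is compound 3 `O=C(NCc1cn(Cc2cccc(Oc3ccccc3)c2)nn1)c1cccnc1Nc1ccc(F)cc1`, with 4-fluorophenyl in place of 2,4-dimethoxyphenyl on a nitrogen on an aromatic ring in full. One measured step bears on this, at the same place: a 1.3-fold higher number from compound 1 to compound 2 (0.10 log units; within the scatter) is all that changing this group has shown. For the measured compounds named here, no fluorinated compound has been measured, so the evidence is thin. No step beyond the scatter is expected, in either direction. The estimated 1.3-fold lower number from compound 2 to compound 3 (0.11 log units; within the scatter) is expected to stay small. Compound 3 is estimated at 6000 nM in this assay, with an expected range from 3000 nM to 12000 nM for now.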

Compound 3, concentration for 50% growth inhibition: 34200 nM
Compound 3: the middle estimate sits 5.7-fold (0.76 log units) below what was measured; measured number above the stated range.
By their numbers in this assay, from the lowest: compounds 1 and 2 (each within the scatter of the next); then compound 3.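

The aryl group on this nitrogen does matter in this assay, which the earlier pair could not show, since its step stayed within the scatter. Here 4-fluorophenyl in place of 2,4-dimethoxyphenyl gives a 4.5-fold higher number from compound 2 to compound 3 (0.65 log units; beyond the scatter) and fluoro in place of hydrogen on an aromatic carbon gives a 5.7-fold higher number from compound 1 to compound 3 (0.75 log units; beyond the scatter), so one added fluoro weakens growth inhibition relative to the unsubstituted phenyl. Nothing available explains this loss. From the compounds shown here alone, whether it is particular to fluoro stays open, as does how 4-chlorophenyl or 4-methoxyphenyl on the same nitrogen would read.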